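The source may hold more compounds than are shown below. What is called first, only, known or untested is meant among the compounds shown, and "the series" means these compounds.

Compound 1 `Clc1ccc(Cn2cc(COc3ccccc3)nn2)cc1`: > 100 ug/mL
Compound 2 `Cc1ccc(OCc2cn(Cc3ccc([N+](=O)[O-])cc3)nn2)cc1`: > 100 ug/mL

Both readings are limits of the assay, not numbers. In an ADME assay on PANC-1 cells (Homo sapiens) for inhibition, read by MTT assay, with a stated time of 48 h (on this read-out lower numbers stand for stronger inhibition of growth and higher numbers for weaker inhibition of growth), compound 1 gives only the limit > 100 ug/mL. Compound 2 likewise gives only the limit > 100 ug/mL in this assay. Compound 2 therefore stands together with compound 1 at the limit of > 100 ug/mL in this assay, at which 2 of the 2 values shown sit, and no number separates them. Compound 3 `Cc1ccc(OCc2cn(Cc3ccc(Cl)cc3)nn2)cc1` differs from compound 2 by chloro in place of nitro on an aromatic carbon. Among the compounds with values here, no measured step shows what this change does. For compound 3 the expected step is a step that the limit leaves unreadable from compound 2 to compound 3, nothing beyond the scatter. Compound 3 is estimated at 150 ug/mL, between 60 ug/mL and 400 ug/mL, most likely again reported only as a limit.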

Compound 3, concentration for 50% growth inhibition: > 100 ug/mL
Compound 3: only a limit was reported (the forecaster's own chance of this, stated with the estimate: 80%); the middle value is on the limit's open side.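

No step to compound 3 can be read from compound 1 or compound 2, since all three readings are limits: the limit of > 100 ug/mL in this assay, at which 3 of the 3 values shown sit.

The compounds shown leave open how strongly each inhibits growth, and whether swapping nitro for chloro or adding methyl changes it.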